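This account rests on a few compounds, and the source may have more. Where it says the series, first, only, none or still open, it means among the compounds named here.

Measured in a functional assay on HeLa cells (Homo sapiens) for cytotoxicity, read by MTT assay, with a stated time of 24 h; a lower number here means a stronger inhibitor, a higher number a weaker inhibitor:
- compound 1 `CCCCCCCCCCCCCCCCCC(=O)Nc1nnc(S[C@@H]2O[C@H](CO)[C@H](O)[C@H](O)[C@H]2O)s1`: 11200 nM
- compound 2 `CCCCCCCC(=O)Nc1nnc(S[C@@H]2O[C@H](CO)[C@H](O)[C@H](O)[C@H]2O)s1`: 50800 nM
- compound 3 `CCCCCCCC/C=C\CCCCCCCCCCCC(=O)Nc1nnc(S[C@@H]2O[C@H](COC(C)=O)[C@H](OC(C)=O)[C@H](OC(C)=O)[C@H]2OC(C)=O)s1`: 58500 nM

Compound 1 has the lowest number of the three, which makes it the strongest inhibitor in this small set, and both other compounds lie beyond the usual scatter from it. Compound 4 `CCCCCCCCCCCCCC(=O)Nc1nnc(S[C@@H]2O[C@H](CO)[C@H](O)[C@H](O)[C@H]2O)s1` keeps the core of compound 1 but has a shorter chain: hydrogen in place of butyl on a saturated chain carbon, ten or more bonds along the chain from a carbonyl carbon.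

For the measured compounds named here, only one measured step bears on this change. Hydrogen in place of decyl on the same chain gave a 4.5-fold higher number from compound 1 to compound 2 (0.66 log units; beyond the scatter). Compound 3 differs from compound 1 in more than one place, so it offers no clean comparison. Butyl is a smaller piece to lose than decyl, though a single step cannot show how evenly the number rises as the chain shortens. A smaller rise in this assay is therefore expected, an estimated step of a 1.8-fold higher number from compound 1 to compound 4 (0.25 log units; within the scatter), which may not stand clear of the scatter. Compound 4 is estimated at 20000 nM, with an expected range of 9000 nM to 45000 nM.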

Compound 4, half-maximal inhibitory concentration: 31000 nM
Compound 4: the middle estimate sits 1.6-fold (0.19 log units) below what was measured, within the range that was stated.
By their numbers in this assay, from the lowest: compound 1; then compounds 4, 2 and 3 (each within the scatter of the next).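

In this assay, taking butyl off the chain of compound 1 is already enough for a step beyond the scatter (a 2.8-fold higher number from compound 1 to compound 4 (0.44 log units; beyond the scatter)), so a clear rise does not require losing a piece as large as decyl. Hexyl in place of hydrogen on the chain of compound 2 gives a step that stays within the scatter (a 1.6-fold lower number from compound 2 to compound 4 (0.21 log units; within the scatter)), so these two chain lengths cannot be told apart here, and only compound 1 stands clear among the three saturated chains. Nothing shown gives a cause for this pattern.

On these data alone, what a longer chain, or an amine or a carboxylic acid in place of the butyl, would do in this assay stays open. Compound 3 differs from compound 4 in more than one place, so it cannot show how much the chain alone counts.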